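Swapping one triazole for another on the same core

This account rests on a few compounds, and the source may have more. Where it says the series, first, only, none or still open, it means among the compounds named here.

Measured compounds in a functional assay on a cell-free system (plasma) with sterol O-acyltransferase, Soat (Rattus norvegicus) as the target; a higher number here means that more compound is needed for the effect, a lower number that less compound is needed:
Compound 1 `Cc1cc(C)c(NC(=O)N(Cc2ccc(-c3nnc(C)o3)cc2)C2CCCCCC2)c(C)c1` is reported only as a limit, > 0.32 mg/kg.
Compound 2 `Cc1cc(C)c(NC(=O)N(Cc2ccc(-c3ccsc3)cc2)C2CCCCCC2)c(C)c1` gives 0.51 mg/kg.
Compound 3 `Cc1cc(C)c(NC(=O)N(Cc2ccc(-n3cncn3)cc2)C2CCCCCC2)c(C)c1` is reported only as a limit, > 1 mg/kg.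

Among the measured compounds shown here, compound 3 therefore stands at the weakest end of what has been measured, and only as a limit rather than a number; compound 1 is likewise known only as a limit (the limit of > 0.32 mg/kg in this assay, at which 1 of the 3 values shown sits), so compound 2 carries the single exact value in this assay.

Compound 4 `Cc1cc(C)c(NC(=O)N(Cc2ccc(-n3nccn3)cc2)C2CCCCCC2)c(C)c1` is the unmeasured partner of compound 3. The change is 2H-1,2,3-triazol-2-yl in place of 1H-1,2,4-triazol-1-yl on an aromatic carbon: the same atoms, joined differently, still a five-membered aromatic ring with 3 hetero atoms hanging from the aromatic carbon para to the large group.

Which measured steps speak to this? a step that the limit leaves unreadable from compound 1 to compound 2 and a step that the two limits leave unreadable from compound 1 to compound 3 are both unreadable, since a limit sits at one or both ends. Only an at least 1.9-fold higher number from compound 2 to compound 3 (0.29 log units; that floor lies within the scatter) is partly readable, and its floor lies within the scatter. Nothing measured separates one nitrogen-linked triazole from another, so the step is expected to be small: a step that the limit leaves unreadable from compound 3 to compound 4, i.e. no change beyond the scatter, with a fair chance the assay again returns only a limit (the limit of > 1 mg/kg in this assay, at which 1 of the 3 values shown sits). Compound 4 is estimated at 1.5 mg/kg, between 0.6 mg/kg and 4 mg/kg.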

Compound 4, dose for half-maximal effect: > 1 mg/kg
Compound 4 gave a limit, no number (the forecaster's own chance of this, stated with the estimate: 55%); the middle value is on the limit's open side.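

With the nitrogens rearranged inside the triazole, this position still gives no exact number in this assay, and the two triazoles share the same limit: the limit of > 1 mg/kg in this assay, at which 2 of the 4 values shown sit.

Among the compounds shown here, the one step that can be partly read is an at least 1.9-fold higher number from compound 2 to compound 4 (0.29 log units; that floor lies within the scatter), and it has the same floor as the step to the other triazole. The steps to compound 4 from compound 3 and from compound 1 cannot be read, with limits at both ends.

As far as these compounds go, whether 2H-1,2,3-triazol-2-yl and 1H-1,2,4-triazol-1-yl differ at all remains open, as does how far either lies past the limit. An amine or a carboxylic acid on the same aromatic carbon would show how this position responds to something other than the five-membered aromatic rings seen so far.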